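Hydroxymethyl for Formyl on a Nucleotide Core

The compounds below may be only part of what the source reports. "The series", "measured", "known", "first", "only" and "open" are said of these compounds alone.

Measured compounds:
Compound 1, `CCc1cn([C@H]2C[C@H](O)[C@@H](OP(=O)(O)O)O2)c(=O)[nH]c1=O`, gives 28200000 nM in an assay on L1210 cells for inhibition of Thymidylate synthase (Mus musculus); on this read-out lower numbers stand for stronger inhibition and higher numbers for weaker inhibition.
Compound 2, `CCCc1cn([C@H]2C[C@H](O)[C@@H](OP(=O)(O)O)O2)c(=O)[nH]c1=O`, gives 8130000 nM in this assay.
Compound 3, `O=Cc1cn([C@H]2C[C@H](O)[C@@H](OP(=O)(O)O)O2)c(=O)[nH]c1=O`, gives 16200000 nM in this assay.

All three compounds share the same core and differ only in the group on one aromatic carbon. Compound 3 stands second highest of the three numbers; its nearest neighbour is compound 1, and the difference between them is a 1.7-fold lower number from compound 1 to compound 3 (0.24 log units; within the scatter), while the other step involving compound 3 is a 2.0-fold higher number from compound 2 to compound 3 (0.30 log units; within the scatter). Both of these steps fall within the scatter, so the three compounds cannot be ranked against each other. Among the compounds with values here, only the step of a 3.5-fold lower number from compound 1 to compound 2 (0.54 log units; beyond the scatter) is beyond the scatter.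

Compound 4, `O=c1[nH]c(=O)n([C@H]2C[C@H](O)[C@@H](OP(=O)(O)O)O2)cc1CO`, is not yet measured. It differs from compound 3 by hydroxymethyl in place of formyl on an aromatic carbon. Within the data shown here, no measured step exchanges a formyl for a hydroxymethyl, so nothing here speaks directly to this change. The two steps that do involve the formyl group, from ethyl and from propyl, were both within the scatter, which suggests that changes at this position have so far moved the numbers little.

Compound 4 is therefore expected to stay close to compound 3, with an estimated 15000000 nM, ranging from 4000000 nM to 60000000 nM, and an expected step of a 1.1-fold lower number from compound 3 to compound 4 (0.03 log units; within the scatter).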

Compound 4, inhibition constant: 269000000 nM
For compound 4 the middle estimate is 18-fold (1.25 log units) below the measured one; measured number above the stated range.
By their numbers in this assay, from the lowest: compounds 2, 3 and 1 (each within the scatter of the next, the first and the last beyond it); then compound 4.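

In this assay this position proves less forgiving than the first three compounds suggested: replacing formyl with hydroxymethyl gives a 17-fold higher number from compound 3 to compound 4 (1.22 log units; beyond the scatter) and so outruns every step among those compounds, with the higher number meaning weaker inhibition. The two groups have the same count of heavy atoms, one carbon and one oxygen, and differ in that the double bond outside the ring is lost and a hydrogen-bond donor is gained, so a swap that leaves those atom counts unchanged can still shift the result strongly. The comparisons with the other two compounds point the same way, as there is a 33-fold higher number from compound 2 to compound 4 (1.52 log units; beyond the scatter) and also a 9.5-fold higher number from compound 1 to compound 4 (0.98 log units; beyond the scatter) on the same read-out, which makes compound 4 the weakest of the four.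

No measurement available here accounts for this loss. The compounds shown also leave open whether the drop belongs to the hydroxy group itself, a question that a methoxymethyl group, an aminomethyl group or a carboxylic acid on the same aromatic carbon could help to settle.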